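This account rests on a few compounds, and the source may have more. Where it says the series, first, only, none or still open, it means among the compounds named here.

Compound 1 `N#CC1=C(N)N(c2ccc(S(N)(=O)=O)cc2)C2=C(C(=O)CCC2)C1c1ccc(Cl)cc1Cl` gives 65% in a functional assay on Ehrlich cells (Mus musculus) for cytotoxicity, read by trypan blue exclusion, with a stated time of 2 h, tested at 50 ug/mL; a lower number here means a weaker effect, a higher number a stronger effect of the compound at the concentration tested. Compound 2 `N#CC1=C(NC(=O)c2ccc([N+](=O)[O-])cc2)N(c2ccc(S(N)(=O)=O)cc2)C2=C(C(=O)CCC2)C1c1ccc(Cl)cc1Cl` gives 50% in this assay. Compound 3 `CN(C)c1ccc(/C=N/C2=C(C#N)C(c3ccc(Cl)cc3Cl)C3=C(CCCC3=O)N2c2ccc(S(N)(=O)=O)cc2)cc1` gives 30% in this assay.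

Compound 3 stands lowest of the three, with compound 2 nearest and compound 1 furthest. Both earlier steps that touched the same position lowered the read-out: a number 35 percentage points lower from compound 1 to compound 3 (beyond the scatter) and a number 20 percentage points lower from compound 2 to compound 3 (beyond the scatter). Compound 4 `CN(C)c1ccc(/C=C/C=N/C2=C(C#N)C(c3ccc(Cl)cc3Cl)C3=C(CCCC3=O)N2c2ccc(S(N)(=O)=O)cc2)cc1` differs from compound 3 by 2-(4-(dimethylamino)phenyl)ethenyl in place of 4-(dimethylamino)phenyl on a carbon with a double bond to nitrogen. For the measured compounds named here, no measured step tests a change of this kind, so it gives only a loose guide; in this assay the expected step of a number 5 percentage points lower from compound 3 to compound 4 (within the scatter) is small and may not lie beyond the scatter. Compound 4 is therefore estimated at 25%, within a range from 10% to 45%.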

Compound 4, a percentage reported as activity, at one concentration (the size of the read-out at that concentration, not a potency): 20%
For compound 4 the middle estimate is 5 percentage points above the measured one; low and high end bracket the measured number.
By their numbers in this assay, from the lowest: compounds 4 and 3 (each within the scatter of the next); then compound 2; then compound 1.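

Putting 2-(4-(dimethylamino)phenyl)ethenyl in place of 4-(dimethylamino)phenyl gives a number 10 percentage points lower from compound 3 to compound 4 (within the scatter) in this assay. Unlike the earlier steps to compound 3, this one does not lie beyond the scatter, so the added ethenyl link has no effect that can be told apart from it at this position. Nothing available explains this result. Still open, going by these compounds, is how a simple methyl group or a longer alkyl chain would read at this carbon. Also open, on these data alone, is what a carboxylic acid in place of the dimethylamino group on the ring would do.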